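Notes on the step from compound 2 to compound 3

The source may hold more compounds than are shown below. What is called first, only, known or untested is meant among the compounds shown, and "the series" means these compounds.

Measured in a functional assay on MCF7 cells (Homo sapiens) for cytotoxicity, read by MTT assay, with a stated time of 48 h; on this read-out lower numbers stand for stronger inhibition and higher numbers for weaker inhibition:
- compound 1 `Cc1n[nH]c2c1C(c1ccc(N(C)C)cc1)C(C(=O)NN)=C(N)N2`: 42600 nM
- compound 2 `Cc1n[nH]c2c1C(c1ccc(N(C)C)cc1)C(C(=O)NNC(N)=S)=C(N)N2`: 5210 nM

Compound 2 holds the lower of the two numbers, 5210 nM. Compound 3 `Cc1n[nH]c2c1C(c1ccc(N(C)C)cc1)C(C(=O)n1ncc(C#N)c1N)=C(N)N2` differs from it by a group of 8 heavy atoms (4 carbon, 4 nitrogen; one five-membered aromatic ring with 2 hetero atoms) in place of a group of 5 heavy atoms (1 carbon, 3 nitrogen, 1 sulfur; no ring), on a carbonyl carbon, with 5-amino-4-cyano-1H-pyrazol-1-yl entering on a carbonyl carbon. Among the measured compounds shown here, only one measured step bears on this: an 8.2-fold lower number from compound 1 to compound 2 (0.91 log units; beyond the scatter), a modest change within the group that now leaves. For the measured compounds named here, no measured compound carries the entering group, so the direction is uncertain. In this assay a modest rise is expected, with the estimated step of a 2.3-fold higher number from compound 2 to compound 3 (0.36 log units; beyond the scatter). The estimate for compound 3 is 12000 nM, with an expected range of 3000 nM to 42000 nM.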

Compound 3, half-maximal inhibitory concentration: 62700 nM
Compound 3: the middle estimate sits 5.2-fold (0.72 log units) below what was measured, and the stated range ends below it.
By their numbers in this assay, from the lowest: compound 2; then compounds 1 and 3 (each within the scatter of the next).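

At this carbonyl carbon, 5-amino-4-cyano-1H-pyrazol-1-yl does not keep what the group in compound 2 gained: in this assay the change gives a large loss (a 12-fold higher number from compound 2 to compound 3 (1.08 log units; beyond the scatter)). Against the simple hydrazide the ring brings no readable change (a 1.5-fold higher number from compound 1 to compound 3 (0.17 log units; within the scatter)), so this aromatic ring performs no better here than the unsubstituted end of compound 1. No evidence on hand accounts for either step.

Open, going by these compounds, is whether the sulfur of compound 2 matters, which a urea with oxygen in its place would test. Also open, on these data alone, is whether the pyrazole without its nitrile behaves the same.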